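A few compounds are considered here, and "the series" means these few. Any claim that something is new, unique, unknown or untested is made for them only; others in the source may bear on it.

Measured compounds, with their values in a functional assay on DLD-1 cells (Homo sapiens) for cytotoxicity, read by colorimetric assay and MTT assay, with a stated time of 3 days, tested at 1 uM; a lower number here means a stronger effect, a higher number a weaker effect of the compound at the concentration tested:
compound 1, `COc1ccc(-c2nc(-c3ccccc3)c(-c3ccc4c(c3)NC(=O)CO4)[nH]2)cc1`, compound 1 gives 96%
compound 2, `O=C1COc2ccc(-c3[nH]c(-c4c[nH]c5ncccc45)nc3-c3ccccc3)cc2N1`, compound 2 gives 97.7%
compound 3, `O=C1COc2ccc(-c3[nH]c(-c4ccc(C(F)(F)F)cc4)nc3-c3ccccc3)cc2N1`, compound 3 gives 95%

All three numbers sit close together near the top of the scale. Compound 3 has the lowest of the three, but its gaps to compound 1 and to compound 2 both lie within the scatter, so no order among them is claimed. The measured steps confirm this: a number 1.7 percentage points higher from compound 1 to compound 2 (within the scatter), a number 1 percentage points lower from compound 1 to compound 3 (within the scatter) and a number 2.7 percentage points lower from compound 2 to compound 3 (within the scatter), none of them beyond the scatter.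

Compound 4, `O=C1COc2ccc(-c3[nH]c(-c4ccc(F)cc4)nc3-c3ccccc3)cc2N1`, differs from compound 3 by fluoro in place of trifluoromethyl on an aromatic carbon. The step that bears most directly on it is a number 1 percentage points lower from compound 1 to compound 3 (within the scatter), which exchanged the group at the same place without moving the read-out beyond the scatter; a number 2.7 percentage points lower from compound 2 to compound 3 (within the scatter), a larger exchange at that place, was likewise within the scatter. Among the compounds with values here, nothing among the measured compounds shows a change at that place shifting this assay. The expected step is therefore a number 1 percentage points higher from compound 3 to compound 4 (within the scatter), not beyond the scatter. Compound 4 is estimated at 96%, with a range of 88% to 103%.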

Compound 4, a percentage reported as activity, at one concentration (the size of the read-out at that concentration, not a potency): 94.8%
The estimate for compound 4 lay 1.2 percentage points above the measured number; the range from low to high includes it.
By their numbers in this assay, from the lowest: compounds 4, 3, 1 and 2 (each within the scatter of the next).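

In this assay, within the data shown here, a number 0.2 percentage points lower from compound 3 to compound 4 (within the scatter) is the first exchange confined to a single substituent, with fluoro in place of trifluoromethyl on an aromatic carbon para to a large group, and the read-out stays within the scatter. The wider exchanges at this place agree: a number 1.2 percentage points lower from compound 1 to compound 4 (within the scatter) puts fluoro in place of methoxy, and a number 2.9 percentage points lower from compound 2 to compound 4 (within the scatter) replaces the whole aromatic group, so four different groups here now give no read-out separated beyond the scatter. No supporting data bear on why this place leaves the read-out unchanged.

All four compounds carry neutral aromatic groups at this place and sit near the top of the scale at one concentration. As far as these compounds go, whether an amine, a carboxylic acid or a longer chain here would shift the read-out remains open, as does the effect of changes elsewhere on the core.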